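The compounds below may be only part of what the source reports. "The series", "measured", "known", "first", "only" and "open" are said of these compounds alone.

Going by the values given here, compound 1, `CC(O)CSc1nc(NCc2ccc(-c3ccccn3)cc2)c2[nH]nc(C(C)C)c2n1`, is one of two compounds measured in a functional assay on HT cells (Homo sapiens) for antiproliferative activity, read by fluorescence, with a stated time of 72 h (on this read-out lower numbers stand for stronger inhibition of growth and higher numbers for weaker inhibition of growth), where compound 1 gives 62 nM. Compound 2, `CC(C)c1n[nH]c2c(NCc3ccc(-c4ccccn4)cc3)nc(SCC(O)CN)nc12`, differs from it only by the amino group added to the chain, and in this assay compound 2 gives 55 nM. Of the two numbers, compound 2 has the lower one, but since a 1.1-fold lower number from compound 1 to compound 2 (0.05 log units; within the scatter), the two compounds cannot be told apart on this read-out.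

Compound 3, `CNCCSc1nc(NCc2ccc(-c3ccccn3)cc2)c2[nH]nc(C(C)C)c2n1`, has not yet been measured. It differs from compound 2 in one place: (methylamino)methyl in place of 2-amino-1-hydroxyethyl on a saturated chain carbon bound to a sulfur.

Among the compounds with values here, only one measured step exists, and it bears on the same chain: a 1.1-fold lower number from compound 1 to compound 2 (0.05 log units; within the scatter). That step changed the chain without moving the number beyond the scatter. Within the data shown here, the change to compound 3 is of a different kind, shortening the chain and removing the hydroxyl while placing a methyl on the nitrogen, so no measured step covers it directly. Among the measured compounds shown here, with the one known step being flat, the expectation for compound 3 is a number close to that of compound 2, with a 1.4-fold higher number from compound 2 to compound 3 (0.13 log units; within the scatter) as the expected step, and an estimated value of 75 nM, ranging from 30 nM to 190 nM.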

Compound 3, concentration for 50% growth inhibition: 56 nM
Compound 3: the middle estimate sits 1.3-fold (0.13 log units) above what was measured; low and high end bracket the measured number.
By their numbers in this assay, from the lowest: compounds 2, 3 and 1 (each within the scatter of the next).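

In this assay, putting (methylamino)methyl in place of 2-amino-1-hydroxyethyl on a saturated chain carbon bound to a sulfur gives a 1.0-fold higher number from compound 2 to compound 3 (0.01 log units; within the scatter). Going by these compounds alone, the earlier pair showed only that an amino group could be added to a chain that keeps its hydroxyl; this result shows that a chain with no hydroxyl and with a methyl on its nitrogen also cannot be told apart from the others, and the comparison with the hydroxyl-only chain reads the same, at a 1.1-fold lower number from compound 1 to compound 3 (0.04 log units; within the scatter). Across these three compounds, then, the read-out does not separate the chains, and no supporting data are available to explain why they read alike.

Going by these compounds, the step to compound 3 removes the hydroxyl, shortens the chain and adds the methyl all at once, so the share of each change stays unknown, and any of them could matter on its own in a different chain. Also open, on these data alone, is whether the read-out stays this flat for a chain ending in a carboxylic acid, a dimethylamino group or a much longer hydrocarbon chain.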